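The source may hold more compounds than are shown below. What is called first, only, known or untested is meant among the compounds shown, and "the series" means these compounds.

Measured so far:
compound 1 `CCCc1nc(C)c2c(C(C)C)nnc(S)n12`: > 48000 nM
compound 2 `CCCCc1nnc(O)n2c(CCC)nc(C)c12`: > 48000 nM
compound 3 `CCCc1nnc(O)n2c(CCC)nc(C)c12`: 16000 nM

In a functional assay for inhibition, with Homo sapiens as the target (a higher number here means a weaker inhibitor, a lower number a stronger inhibitor), compound 3 gives 16000 nM. For compound 2 the value > 48000 nM is a limit of the assay, not a number. For compound 1 the value > 48000 nM is likewise a limit. The change hydrogen in place of methyl on a saturated chain carbon, three bonds along the chain from an aromatic carbon gave an at least 3.0-fold lower number from compound 2 to compound 3 (0.47 log units; beyond the scatter). Compound 4 `CCCc1nc(C)c2c(CC)nnc(S)n12` is not yet measured; it differs from compound 1 by hydrogen in place of methyl on a saturated chain carbon bound to an aromatic carbon and a saturated chain carbon, the same kind of change, though here the place is a saturated chain carbon bound to an aromatic carbon and a saturated chain carbon rather than one three bonds along the chain from an aromatic carbon. How the core of compound 1 differs from that of compound 2 is not broken down here. As far as these compounds go, because compound 1 sits at the limit of > 48000 nM in this assay, at which 2 of the 3 values shown sit, its true value is unknown, so the step to compound 4 is expected to be about an at least 1.2-fold lower number from compound 1 to compound 4 (0.07 log units; that floor lies within the scatter), resting only on compound 2 to compound 3. Compound 4 is expected near 40000 nM, between 12000 nM and 200000 nM.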

Compound 4, half-maximal inhibitory concentration: > 48000 nM
Compound 4: only a limit was reported; the forecaster's own chance of this, stated with the estimate: 55%; at least 1.2-fold (0.07 log units) between middle value and limit.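

Among the compounds shown here, no step from compound 1 to compound 4 can be read, because both values are limits of the assay, not numbers: the limit of > 48000 nM in this assay, at which 3 of the 4 values shown sit. The compounds shown leave open whether going from isopropyl to ethyl changes inhibition at all, and how strong either compound truly is.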